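This account rests on a few compounds, and the source may have more. Where it says the series, first, only, none or still open, it means among the compounds named here.

Of the compounds shown here, three sharing one core have been measured in an ADME assay on CHO cells (Cricetulus griseus) for inhibition, read by MTT assay; on this read-out higher numbers stand for weaker inhibition and lower numbers for stronger inhibition. Compound 1 `CCN(CC)Cc1ccc(Nc2nc3ccccc3[nH]2)cc1O` gives > 50000 nM, which is a limit of the assay and not a number. Compound 2 `CCN(CC)Cc1ccc(Nc2nc3ccccc3n2Cc2ccc(C#N)cc2)cc1O`, with a 4-cyanobenzyl group on an aromatic nitrogen, gives 39000 nM. Compound 3 `CCN(CC)Cc1ccc(Nc2nc3ccccc3n2Cc2ccc(F)cc2)cc1O`, with a 4-fluorobenzyl group in that place, gives 45800 nM, which lies within the scatter of the value for compound 2.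

Compound 4 `CCN(CC)Cc1ccc(Nc2nc3ccccc3n2Cc2ccc(C(F)(F)F)cc2)cc1O` has not yet been measured. It differs from compound 3 by trifluoromethyl in place of fluoro on an aromatic carbon, para to a large group (trifluoromethyl in place of fluoro on an aromatic carbon). The nearest guide is the swap at that same place, fluoro in place of cyano, which gave a 1.2-fold higher number from compound 2 to compound 3 (0.07 log units; within the scatter). Putting a benzyl group on the nitrogen of compound 1 gave an at least 1.2-fold lower number from compound 1 to compound 2 (0.10 log units; that floor lies within the scatter) and an at least 1.0-fold lower number from compound 1 to compound 3 (0.03 log units; that floor lies within the scatter), but both of these steps start from a limit. On this evidence, compound 4 is expected to stay within the scatter of compound 3. The expected step is a 1.1-fold lower number from compound 3 to compound 4 (0.06 log units; within the scatter), which is no real change. Compound 4 is estimated at 40000 nM, with an expected range of 22000 nM to 50000 nM.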

Compound 4, half-maximal inhibitory concentration: 41500 nM
Estimate against measurement, compound 4: 1.0-fold (0.02 log units) below; low and high end bracket the measured number.
By their numbers in this assay, from the lowest: compounds 2, 4 and 3 (each within the scatter of the next). At a limit, above all of these: compound 1.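

In this assay, trifluoromethyl at this place, on an aromatic carbon para to a large group, gives a 1.1-fold lower number from compound 3 to compound 4 (0.04 log units; within the scatter) and a 1.1-fold higher number from compound 2 to compound 4 (0.03 log units; within the scatter), so a group of 4 heavy atoms in place of 1 leaves the number where it was, and fluoro, cyano and trifluoromethyl cannot be told apart here. Placing 4-(trifluoromethyl)benzyl on the aromatic nitrogen gives an at least 1.2-fold lower number from compound 1 to compound 4 (0.08 log units; that floor lies within the scatter), which is only a floor, so this third benzyl step, like the two before it, does not show how much the benzyl group changes the number. Compound 1 remains a limit and not a number, and it is the only such value in this set: the limit of > 50000 nM in this assay, at which 1 of the 4 values shown sits.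

On these data alone, whether an amine or a carboxylic acid at this same place would move the number beyond the scatter stays open. Also open, as far as these compounds go, is what a plain benzyl group, with hydrogen at this place, would give, a value that could show whether fluoro, cyano or trifluoromethyl changes anything at all relative to hydrogen.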